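The compounds below may be only part of what the source reports. "The series", "measured", "known", "first", "only" and "open" are said of these compounds alone.

Measured compounds in a functional assay on HCT-116 cells (Homo sapiens) for cytotoxicity, read by sulforhodamine B assay, with a stated time of 48 h, tested at 1 uM; on this read-out higher numbers stand for a weaker effect at the one concentration tested and lower numbers for a stronger effect:
compound 1 `COc1ccc(-c2cc(/C=C/C(=O)c3ccc(OC)c(OC)c3)[nH]n2)cc1`, 51%
compound 2 `COc1ccc(-c2cc(/C=C/C(=O)c3ccc(N)cc3)[nH]n2)cc1OC`, 87%
compound 3 `COc1ccc(C(=O)/C=C/c2cc(-c3cc(OC)c(OC)c(OC)c3)n[nH]2)cc1`, 72%

Compound 3 stands second highest of the three numbers in this assay. Its nearest neighbour is compound 2, whose number is higher by a gap beyond the scatter, while compound 1, the furthest, gives a number lower by a gap beyond the scatter. For the measured compounds named here, no pair of measured compounds differs in a single place, so no step isolates any one structural change.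

Compound 4 `COc1cc(-c2cc(/C=C/C(=O)c3ccc(F)c(F)c3)[nH]n2)cc(OC)c1OC` has not yet been measured. Compared with compound 3 it carries 3,4-difluorophenyl in place of 4-methoxyphenyl on a carbonyl carbon. Going by the values given here, nothing among the measured compounds shows what exchanging a 4-methoxyphenyl for a 3,4-difluorophenyl on a carbonyl carbon does in this assay, so the expectation rests on the spread of the three numbers alone. Compound 4 is expected to land at 62%, between 38% and 86%. The step from compound 3 to compound 4 is estimated at a number 10 percentage points lower from compound 3 to compound 4 (within the scatter), a move downward that may well stay within the scatter.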

Compound 4, a percentage reported as activity, at one concentration (the size of the read-out at that concentration, not a potency): 113%
For compound 4 the middle estimate is 51 percentage points below the measured one; measured number outside the range, above it.
By their numbers in this assay, from the lowest: compound 1; then compound 3; then compound 2; then compound 4.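

In this assay, for the compounds shown here, changing the group on the carbonyl carbon gives a number 41 percentage points higher from compound 3 to compound 4 (beyond the scatter), the only comparison here that isolates a single structural change. It shows that the group on this carbonyl carbon matters in this assay, and that this exchange moves the read-out towards a weaker effect at the one concentration tested. No measurement available here accounts for the size of this step.

As far as these compounds go, whether the step comes from losing the 4-methoxyphenyl or from gaining the 3,4-difluorophenyl stays open, and an unsubstituted phenyl, or a phenyl carrying a single fluorine or a hydroxyl group, at the same place would help separate the two. Also open, from the compounds shown here alone, is whether the same exchange has a similar effect on the core of compound 1.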